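This account rests on a few compounds, and the source may have more. Where it says the series, first, only, none or still open, it means among the compounds named here.

Compound 1 `Cc1nc(S(C)(=O)=O)ccc1Oc1ncnc(OC2CCN(C(=O)OC3CCC3)CC2)c1F` is the reference point of this small series. In a functional assay on isolated protein for inhibition of Glucose-dependent insulinotropic receptor (Homo sapiens), read by HTRF and cAMP accumulation (on this read-out higher numbers stand for an effect only at larger amounts of compound and lower numbers for an effect already at smaller amounts), compound 1 gives 13.6 nM, the lowest number of the three measured compounds. Compound 3 `Cc1nc(S(C)(=O)=O)ccc1Oc1ncnc(OC2CCN(C(=O)OC3(C(F)(F)F)CCC3)CC2)c1F` gives 14.3 nM, a step of a 1.1-fold higher number from compound 1 to compound 3 (0.02 log units; within the scatter), whereas compound 2 `Cc1nc(S(C)(=O)=O)ccc1Oc1ncnc(OC2CCN(C(=O)O[C@@H](C)CF)CC2)c1F` gives 186 nM, a step of a 14-fold higher number from compound 1 to compound 2 (1.14 log units; beyond the scatter). The step from compound 2 to compound 3 is a 13-fold lower number from compound 2 to compound 3 (1.11 log units; beyond the scatter).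

Compound 4 `Cc1nc(S(C)(=O)=O)ccc1Oc1ncnc(OC2CCN(C(=O)C(C)(C)F)CC2)c1F` is not yet measured. Its change from compound 1 is 1-fluoro-1-methylethyl in place of cyclobutyloxy on a carbonyl carbon. Going by the values given here, the step that bears most on this change is the one from compound 1 to compound 2, where a small open-chain fluorinated group on the oxygen next to the carbonyl group gave a 14-fold higher number from compound 1 to compound 2 (1.14 log units; beyond the scatter); compound 4 likewise carries a small open-chain fluorinated group, here with the oxygen removed as well, so no measured step covers the loss of the oxygen directly. On this basis compound 4 is expected to give a higher number in this assay, with a step estimated at a 7.4-fold higher number from compound 1 to compound 4 (0.87 log units; beyond the scatter). The estimate for compound 4 is 100 nM, between 25 nM and 400 nM.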

Compound 4, half-maximal effective concentration: 76.3 nM
Compound 4: the middle estimate sits 1.3-fold (0.12 log units) above what was measured, within the range that was stated.
By their numbers in this assay, from the lowest: compounds 1 and 3 (each within the scatter of the next); then compound 4; then compound 2.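

In this assay the carbonyl carbon does not take the loss of the cyclobutyloxy group without a cost: the change to 1-fluoro-1-methylethyl brings a 5.6-fold higher number from compound 1 to compound 4 (0.75 log units; beyond the scatter) and, set against the trifluoromethyl-bearing ring, a 5.3-fold higher number from compound 3 to compound 4 (0.73 log units; beyond the scatter). Against the other open-chain fluorinated group, which keeps its oxygen on the carbonyl, the same group gives a 2.4-fold lower number from compound 2 to compound 4 (0.39 log units; beyond the scatter), so an oxygen on the carbonyl is not needed for the lower numbers among the open-chain groups shown here. No measured evidence on these compounds bears on the size of these steps.

The compounds shown leave the oxygen and the ring unseparated, and a cyclobutyl group set directly on the carbonyl carbon would speak to that. Also open, from the compounds shown here alone, is how an amine or a longer chain would read at this place.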